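Working notes: from compound 2 to compound 4

The source may hold more compounds than are shown below. What is called first, only, known or untested is meant among the compounds shown, and "the series" means these compounds.

Three compounds have numbers in an assay on isolated protein for inhibition of DNA topoisomerase 1 (Homo sapiens), with a stated time of 30 min, tested at 100 uM; a lower number here means a weaker effect, a higher number a stronger effect of the compound at the concentration tested. Compound 1 `Oc1ccc(-c2cc(-c3ccccn3)nc(-c3ccccc3Cl)c2)cc1` gives 5.2%. Compound 2 `Oc1ccc(-c2cc(-c3ccc(Cl)cc3)nc(-c3cccnc3)c2)cc1` gives 18.8%. Compound 3 `Oc1cccc(-c2cc(-c3ccncc3)nc(-c3cccc(Cl)c3)c2)c1` gives 0%. Compound 2 stands highest of the three: its gaps to compound 1 and to compound 3 are both beyond the scatter, so at the tested concentration it is the strongest of the set. Compound 1 and compound 3 lie within the scatter of each other, and no order between them is claimed. Going by the values given here, no pair of measured compounds differs in only one place, so no single structural step has yet been seen in isolation in this assay.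

Compound 4 `Oc1ccc(-c2cc(-c3ccc(Cl)cc3)nc(-c3cccs3)c2)cc1` differs from compound 2 in one place: thiophen-2-yl in place of pyridin-3-yl on an aromatic carbon. Among the compounds with values here, with no measured step of this kind at hand, the change is expected to stay within the scatter, leaning slightly downward; the step of a number 5.8 percentage points lower from compound 2 to compound 4 (within the scatter) is the expected size in this assay. Compound 4 is estimated at 13%, with a range from 0% to 30%.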

Compound 4, a percentage reported as inhibition, at one concentration (the size of the read-out at that concentration, not a potency): 38.8%
The estimate for compound 4 lay 25.8 percentage points below the measured number; measured number outside the range, above it.
By their numbers in this assay, from the lowest: compounds 3 and 1 (each within the scatter of the next); then compound 2; then compound 4.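

Going by these compounds alone, this position, next to the ring nitrogen, is the first place where a single change can be read in this assay: thiophen-2-yl in place of pyridin-3-yl comes with a number 20 percentage points higher from compound 2 to compound 4 (beyond the scatter). The position therefore tolerates a five-membered aromatic ring, and the read-out at the tested concentration differs clearly between these two rings. Ring size and hetero atom change together in this step, and no measurement here bears on what lies behind the difference.

The compounds shown leave open whether the higher number belongs to the sulfur atom, to the five-membered ring, or to the loss of the pyridine nitrogen, and how a phenyl ring, a furan-2-yl ring or an amine at this position would compare. Also open, going by these compounds, is whether the same step holds when the 4-chlorophenyl or 4-hydroxyphenyl group is changed.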